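Swapping Trifluoromethyl for Methyl in Three Inactive Compounds

The source may hold more compounds than are shown below. What is called first, only, known or untested is meant among the compounds shown, and "the series" means these compounds.

Compound 1 `Cc1c(O)ccc2c1[C@H](Cn1cc(-c3ccc(C(F)(F)F)cc3)nn1)[C@@]13CC(=O)[C@@](C)(CC[C@@H]21)C3` and compound 2 `Cc1ccc(-c2cn(C[C@H]3c4c(ccc(O)c4C)[C@@H]4CC[C@@]5(C)C[C@]43CC5=O)nn2)cc1` share one core and differ only by methyl in place of trifluoromethyl on an aromatic carbon. In a functional assay on MCF7 cells (Homo sapiens) for cytotoxicity, read by MTT assay, with a stated time of 4 days (a higher number here means a weaker inhibitor, a lower number a stronger inhibitor), compound 1 gives > 20000 nM, which is a limit of the assay rather than a number. In this assay compound 2 gives > 20000 nM, again a limit. The step that the two limits leave unreadable from compound 1 to compound 2 therefore cannot be sized. Compound 3 `C=C1C[C@]23C[C@@]1(O)CC[C@@H]2c1cccc(C)c1[C@@H]3Cn1cc(-c2ccc(C(F)(F)F)cc2)nn1` is built on a different core; the difference between the two cores is not broken down here. In this assay compound 3 gives > 20000 nM, which is also a limit. Because (the limit of > 20000 nM in this assay, at which 3 of the 3 values shown sit), none of the three measured compounds shows measurable inhibition of these cells.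

Compound 4 `C=C1C[C@]23C[C@@]1(O)CC[C@@H]2c1cccc(C)c1[C@@H]3Cn1cc(-c2ccc(C)cc2)nn1` has not been measured. It differs from compound 3 by methyl in place of trifluoromethyl on an aromatic carbon, and the place of this change reads word for word as it does between compound 1 and compound 2, so it is the same change. In this assay the expected step is a step that the limit leaves unreadable from compound 3 to compound 4, because the limit of > 20000 nM in this assay, at which 3 of the 3 values shown sit, left both members of the earlier pair unreadable. Compound 4 is estimated at 40000 nM, and most likely this assay will again report only a limit.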

Compound 4, half-maximal inhibitory concentration: > 20000 nM
Compound 4 was reported as a limit; the forecaster's own chance of this, stated with the estimate: 90%; the middle value does not contradict the limit.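

In this assay compound 4 gives > 20000 nM, a limit of the assay and not a number. The step from compound 3 to compound 4 therefore cannot be read, so methyl in place of trifluoromethyl yields no new size: the limit of > 20000 nM in this assay, at which 4 of the 4 values shown sit. Left open is how strongly, if at all, any of the four compounds inhibits these cells, and whether this swap changes that.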